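Sulfonamide amine variation on the alkyne aryloxyacetic acid series

This account rests on a few compounds, and the source may have more. Where it says the series, first, only, none or still open, it means among the compounds named here.

Compound 1 `Cc1ccc(S(=O)(=O)N(C)C(C)C)cc1C#Cc1cc(Cl)ccc1OCC(=O)O` and compound 2 `Cc1ccc(S(=O)(=O)N2CCCCC2C)cc1C#Cc1cc(Cl)ccc1OCC(=O)O` share one core and differ only at the sulfonyl sulfur. In an assay on CHO cells for displacement of a labelled ligand from prostaglandin D2 receptor 2 (Homo sapiens), read by scintillation counting (a lower number here means a stronger inhibitor, a higher number a weaker inhibitor), compound 1 gives 3.8 nM and compound 2 gives 1.9 nM; the step of a 2.0-fold lower number from compound 1 to compound 2 (0.30 log units; within the scatter) lies within the scatter, so compound 2 holds the lowest of the two numbers without separating from compound 1. Compound 3 `CCN(CC)S(=O)(=O)c1ccc(C)c(C#Cc2cc(Cl)ccc2OCC(=O)O)c1` brings (diethylamino in place of 2-methylpiperidin-1-yl on a sulfonyl sulfur). Among the measured compounds shown here, the only step at this position, a 2.0-fold lower number from compound 1 to compound 2 (0.30 log units; within the scatter), was within the scatter, so in this assay the expected step to compound 3 is a 1.6-fold higher number from compound 2 to compound 3 (0.20 log units; within the scatter), none beyond the scatter. Compound 3 is estimated at 3 nM, between 1.4 nM and 7 nM.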

Compound 3, inhibition constant: 3.4 nM
Compound 3: middle estimate off by 1.1-fold (0.05 log units), on the low side; the range from low to high includes it.
By their numbers in this assay, from the lowest: compounds 2, 3 and 1 (each within the scatter of the next).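

In this assay, a 1.8-fold higher number from compound 2 to compound 3 (0.25 log units; within the scatter) and a 1.1-fold lower number from compound 1 to compound 3 (0.05 log units; within the scatter) both stay within the scatter. Among these three compounds, the ring of 2-methylpiperidin-1-yl is therefore not needed to stay at this level on the sulfonyl sulfur, since the ring-free diethylamino reads the same within the scatter.

Still open, going by these compounds, is whether a morpholin-4-yl ring, a carboxylic acid on the amine part, or a longer chain than ethyl would give a step beyond the scatter at this position. No supporting data bear on this result.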